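The source may hold more compounds than are shown below. What is called first, only, known or untested is meant among the compounds shown, and "the series" means these compounds.

Of the compounds shown here, three have been measured in an assay on HEK293 cells for displacement of a labelled ligand from Melanocortin receptor 4 (Homo sapiens); on this read-out lower numbers stand for stronger inhibition and higher numbers for weaker inhibition. Compound 1 `COc1cc(CC(C)C(=O)N2CCN(c3ccc(C(F)(F)F)cc3[C@@H](N)CC(C)C)CC2)ccc1Cl` gives 230 nM. Compound 2 `CC(C)C[C@H](N)c1cc(C(F)(F)F)ccc1N1CCN(C(=O)CCNC2CCCCC2)CC1` gives 4800 nM, the highest number of the three, with compound 1 nearest to it and compound 3 furthest. Compound 3 `COc1cc(Cl)ccc1C[C@@H](C)C(=O)N1CCN(c2ccc(C)cc2[C@@H](N)CC(C)C)CC1` gives 8.1 nM. For the measured compounds named here, the only single-point step among them is a 21-fold higher number from compound 1 to compound 2 (1.32 log units; beyond the scatter), a large move to weaker binding when the benzyl-bearing group on the carbonyl carbon is exchanged for a chain ending in an amine.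

Compound 4 `COc1ccc(CC(C)C(=O)N2CCN(c3ccc(C(F)(F)F)cc3[C@@H](N)CC(C)C)CC2)cc1` has not yet been measured in this assay. It differs from compound 2 in one place: 1-(4-methoxybenzyl)ethyl in place of 2-(cyclohexylamino)ethyl on a carbonyl carbon. Going by the values given here, this change largely reverses the one step seen so far, restoring a benzyl-type group to the carbonyl carbon, though the ring it carries is not the same as in compound 1. Given the size of a 21-fold higher number from compound 1 to compound 2 (1.32 log units; beyond the scatter), a large step to a lower number is expected, roughly a 12-fold lower number from compound 2 to compound 4 (1.08 log units; beyond the scatter). Compound 4 is therefore estimated at 400 nM, within a range of 100 nM to 1600 nM.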

Compound 4, inhibition constant: 120 nM
For compound 4 the middle estimate is 3.3-fold (0.52 log units) above the measured one; measured number inside the range.
By their numbers in this assay, from the lowest: compound 3; then compounds 4 and 1 (each within the scatter of the next); then compound 2.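

Restoring a benzyl-type group on the carbonyl carbon gives a large change (a 40-fold lower number from compound 2 to compound 4 (1.60 log units; beyond the scatter)), so this position responds strongly even when the ring is not the one in compound 1. By contrast, exchanging 4-chloro-3-methoxyphenyl for 4-methoxyphenyl gives a step within the scatter (a 1.9-fold lower number from compound 1 to compound 4 (0.28 log units; within the scatter)), so these two compounds show no real effect of that ring change. No available evidence explains either result.

The large step replaces the nitrogen-bearing chain and changes the non-aromatic ring to an aromatic one together, so these compounds cannot separate the two changes. A 1-(cyclohexylmethyl)ethyl group, with the non-aromatic ring but no nitrogen, or a 2-(phenylamino)ethyl group, with the nitrogen and an aromatic ring, would help pull them apart.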